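A few compounds are considered here, and "the series" means these few. Any claim that something is new, unique, unknown or untested is made for them only; others in the source may bear on it.

In a functional assay on MCF7 cells (Homo sapiens) for cytotoxicity, read by sulforhodamine B assay, with a stated time of 48 h (a higher number here means a weaker inhibitor, a lower number a stronger inhibitor), compound 3 `CCOC(=O)c1c(-c2ccc(OC)cc2)c(C#N)c(=O)n(/N=C(\C)c2ccc(S(=O)(=O)N3CCCCC3)cc2)c1N` gives 51200 nM, the highest of the three numbers, although its distances to the other two stay within the scatter. Compound 1 `CCOC(=O)c1c(-c2ccc(C)cc2)c(C#N)c(=O)n(/N=C(\C)c2ccc(S(=O)(=O)N3CCCCC3)cc2)c1N` gives 37900 nM in this assay, and compound 2 `CCOC(=O)c1c(-c2ccc(O)cc2)c(C#N)c(=O)n(/N=C(\C)c2ccc(S(=O)(=O)N3CCCCC3)cc2)c1N` gives 25500 nM. The measured steps are a 1.5-fold lower number from compound 1 to compound 2 (0.17 log units; within the scatter), a 1.4-fold higher number from compound 1 to compound 3 (0.13 log units; within the scatter) and a 2.0-fold higher number from compound 2 to compound 3 (0.30 log units; within the scatter), none of them beyond the scatter. Compound 4 `CCOC(=O)c1c(-c2ccc(O)c(OC)c2)c(C#N)c(=O)n(/N=C(\C)c2ccc(S(=O)(=O)N3CCCCC3)cc2)c1N` differs from compound 3 by 4-hydroxy-3-methoxyphenyl in place of 4-methoxyphenyl on an aromatic carbon. All three measured steps bear on this change, as each exchanges the group on the same aromatic carbon among methyl, hydroxy and methoxy, and none moved the number beyond the scatter. Compound 4 keeps the methoxy of compound 3 and adds the hydroxy seen in compound 2, so one expects at most a small shift, if any, toward the lower number of compound 2. The expected step is a 1.4-fold lower number from compound 3 to compound 4 (0.15 log units; within the scatter). For compound 4 the estimate in this assay is 36000 nM, with a range from 17000 nM to 75000 nM.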

Compound 4, half-maximal inhibitory concentration: 38700 nM
For compound 4 the middle estimate is 1.1-fold (0.03 log units) below the measured one; the measured number falls inside the stated range.
By their numbers in this assay, from the lowest: compounds 2, 1, 4 and 3 (each within the scatter of the next).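

In this assay, the phenyl group at this position took a second substituent without the number leaving the scatter: a methoxy on the hydroxyphenyl group gives a 1.5-fold higher number from compound 2 to compound 4 (0.18 log units; within the scatter), and 4-hydroxy-3-methoxyphenyl in place of 4-methoxyphenyl gives a 1.3-fold lower number from compound 3 to compound 4 (0.12 log units; within the scatter), while in place of 4-methylphenyl it gives a 1.0-fold higher number from compound 1 to compound 4 (0.01 log units; within the scatter). The earlier steps shown here only exchanged one small group for another, whereas this larger group, with one more heavy atom than 4-methoxyphenyl, shows that the position also tolerates two groups on the phenyl ring with no step beyond the scatter. No available evidence accounts for these numbers.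

On these data alone, whether any change at this position can move the number beyond the scatter remains open. An amine or a carboxylic acid on the phenyl ring, or a longer chain in place of the methoxy, might show this.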